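Primary sulfamoyl with fluorine replaces carbamoyl on the aryl arm

The compounds below may be only part of what the source reports. "The series", "measured", "known", "first", "only" and "open" are said of these compounds alone.

Measured compounds:
Compound 1, `CCCS(=O)(=O)Nc1ccc(F)c(C(=O)c2n[nH]c3ncc(-c4ccc(S(=O)(=O)NC)cc4)cc23)c1F`: 14%
Compound 2, `CCCS(=O)(=O)Nc1ccc(F)c(C(=O)c2n[nH]c3ncc(-c4ccc(C(N)=O)cc4)cc23)c1F`: 4%

Both compounds share one core and differ only in the group on the pendant aryl ring. In an assay for binding affinity to dual specificity mitogen-activated protein kinase kinase 4 (Homo sapiens), read by KINOMEscan, tested at 10 nM (a higher number here means a weaker effect of the compound at the concentration tested, a lower number a stronger effect), compound 1 gives 14% and compound 2 gives 4%. Among the measured compounds shown here, the single measured step, a number 10 percentage points lower from compound 1 to compound 2 (within the scatter), puts the two numbers within the scatter of each other, so compound 2 stands level with compound 1 on what has been measured rather than apart from it.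

Compound 3, `CCCS(=O)(=O)Nc1ccc(F)c(C(=O)c2n[nH]c3ncc(-c4ccc(S(N)(=O)=O)cc4F)cc23)c1F`, has not yet been tested. Its change from compound 2 is 2-fluoro-4-sulfamoylphenyl in place of 4-carbamoylphenyl on an aromatic carbon. For the measured compounds named here, the only step that bears on this is the one from compound 1 to compound 2, which swapped a methylsulfamoyl for a carbamoyl without moving the number beyond the scatter; compound 3 returns to a sulfamoyl group, now unsubstituted on nitrogen, with a fluorine added to the ring. Given that this assay did not separate compound 1 from compound 2, compound 3 is expected to stay in the same low region, and the expected step of a number 5 percentage points higher from compound 2 to compound 3 (within the scatter) is none beyond the scatter. The estimate for compound 3 is 9%, with a range from 2% to 30%.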

Compound 3, a percentage reported as activity, at one concentration (the size of the read-out at that concentration, not a potency): 9.4%
Beside the measured number, compound 3's estimate is 0.4 percentage points below it; low and high end bracket the measured number.
By their numbers in this assay, from the lowest: compounds 2, 3 and 1 (each within the scatter of the next).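

At this position on the aromatic carbon, in this assay, putting 2-fluoro-4-sulfamoylphenyl in place of 4-carbamoylphenyl gives a number 5.4 percentage points higher from compound 2 to compound 3 (within the scatter) and putting it in place of 4-(methylsulfamoyl)phenyl gives a number 4.6 percentage points lower from compound 1 to compound 3 (within the scatter) as the second reading of the same arm. The earlier pair had shown only that a carbamoyl and a methylsulfamoyl could not be told apart here; the three arms now stand level with one another, so an unsubstituted sulfamoyl carrying a ring fluorine also leaves the read-out unseparated from both. No measurement given here offers any explanation for this lack of separation.

On these data alone, what the ring fluorine does on its own stays open, as does the part played by the methyl on the sulfamoyl nitrogen, since compound 3 differs from compound 1 in both at once. As far as these compounds go, it is also open whether an amine or a carboxylic acid on the aryl arm, in place of these groups, would stay level with the three compounds or move beyond the scatter.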